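A few compounds are considered here, and "the series" means these few. Any claim that something is new, unique, unknown or untested is made for them only; others in the source may bear on it.

Measured so far in a functional assay on muscle tissue for agonist activity at histamine H2 receptor (Cavia porcellus); a lower number here means a less potent compound, a higher number a more potent compound, by a factor of ten per unit of this negative logarithm:
compound 1 `N=C(NCCCc1c[nH]cn1)NCCC(c1ccc(Cl)cc1)c1ccccn1` gives 7.39
compound 2 `N=C(NCCCc1c[nH]cn1)NCCC(c1ccc(Br)cc1)c1ccccn1` gives 6.97
compound 3 `N=C(NCCCc1c[nH]cn1)NCCC(c1cccc(C(F)(F)F)c1)c1ccccn1` gives 7.44

Compound 3 and compound 1 lie within the scatter of each other; compound 3 stands apart only from compound 2, by the step of a number 0.47 log units higher from compound 2 to compound 3 (beyond the scatter), which is modest. Compound 4 `N=C(NCCCc1c[nH]cn1)NCCC(c1ccc(Cl)c(Cl)c1)c1ccccn1` has not been measured. It differs from compound 3 in one place: 3,4-dichlorophenyl in place of 3-(trifluoromethyl)phenyl on a saturated chain carbon bound to an aromatic carbon and a saturated chain carbon. Within the data shown here, the steps that bear on this change are a number 0.05 log units higher from compound 1 to compound 3 (within the scatter), a number 0.47 log units higher from compound 2 to compound 3 (beyond the scatter) and a number 0.42 log units lower from compound 1 to compound 2 (beyond the scatter): swapping the groups on this phenyl ring moved this assay at most modestly. For compound 4 no step beyond the scatter is therefore expected, a number 0.14 log units lower from compound 3 to compound 4 (within the scatter), and its estimated value is 7.3 with a range from 6.7 to 7.9.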

Compound 4, negative logarithm of the half-maximal effective concentration: 7.54
Estimate against measurement, compound 4: 0.24 log units below, within the range that was stated.
By their numbers in this assay, from the lowest: compound 2; then compounds 1, 3 and 4 (each within the scatter of the next).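

In this assay, chloro in place of hydrogen on an aromatic carbon gives (a number 0.15 log units higher from compound 1 to compound 4 (within the scatter)), and 3,4-dichlorophenyl in place of 3-(trifluoromethyl)phenyl gives (a number 0.10 log units higher from compound 3 to compound 4 (within the scatter)), so among these compounds this ring carries a second substituent with no change beyond the scatter. Only the comparison with the bromo compound stands out, at (a number 0.57 log units higher from compound 2 to compound 4 (beyond the scatter)). Nothing available here explains any of these steps.

On these data alone, whether a methoxy group or an amine on this phenyl ring would keep the number in this range remains open. So does the effect of a second bromo.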